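Anticonvulsant series: pyrrolidine in place of ethylamino

A few compounds are considered here, and "the series" means these few. Any claim that something is new, unique, unknown or untested is made for them only; others in the source may bear on it.

Two compounds of this set have been run in a functional assay on the whole organism with Rattus norvegicus as the target, in the maximal electroshock model; on this read-out lower numbers stand for an effect already at smaller amounts and higher numbers for an effect only at larger amounts of compound. Compound 1 `CNc1ncnc2c1ncn2Cc1ccccc1C` gives 10 mg/kg in this assay. Compound 2 `CCNc1ncnc2c1ncn2Cc1ccccc1F` gives 4.9 mg/kg in this assay, the lower of the two numbers; the gap to compound 1 lies beyond the usual scatter, so compound 2 is the more potent of the pair as far as these two numbers go. No pattern beyond these two compounds can be claimed.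

Compound 3 `Fc1ccccc1Cn1cnc2c(N3CCCC3)ncnc21` has not been measured. Relative to compound 2 it carries pyrrolidin-1-yl in place of ethylamino on an aromatic carbon on the shared core. For the measured compounds named here, no measured pair shows the effect of such a change here, so the expectation rests on compound 2 alone. A step toward somewhat higher numbers, possibly still within the scatter, is expected; the estimated step is a 1.4-fold higher number from compound 2 to compound 3 (0.15 log units; within the scatter). Compound 3 is thus estimated at 7 mg/kg in this assay, within a range from 3 mg/kg to 18 mg/kg.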

Compound 3, dose for half-maximal effect: 12.5 mg/kg
The estimate for compound 3 lay 1.8-fold (0.25 log units) below the measured number; low and high end bracket the measured number.
By their numbers in this assay, from the lowest: compound 2; then compounds 1 and 3 (each within the scatter of the next).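

For the compounds shown here, at this aromatic carbon on the shared core, pyrrolidin-1-yl in place of ethylamino gives a 2.6-fold higher number from compound 2 to compound 3 (0.41 log units; beyond the scatter) in this assay, the only measured step at this position and a modest one. The group here therefore matters to the read-out, yet the swap of ethylamino, which has a hydrogen-bond donor, for a five-membered ring without one leaves a measurable effect, with compound 3 at 12.5 mg/kg. Nothing at hand accounts for the step.

This one pair cannot separate the contributions of the ring, the missing donor and the larger group. Dimethylamino, which has no ring and no hydrogen-bond donor, and the six-membered piperidin-1-yl would be needed to tell these apart, so how either reads at this position remains open.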